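Amide-nitrogen aryl swap in the furan-carboxamide phenol series

The source may report more compounds than this note shows. Statements on the series, on what has been measured and on what is new or still open speak of the compounds shown alone.

Three measured compounds share the core and differ only in their aryl groups. Compound 1 `Cc1ccccc1N(C)C(=O)c1ccc(-c2ccc(O)c(F)c2)o1` gives 10 nM in an assay on T47D cells for inhibition of 17-beta-hydroxysteroid dehydrogenase type 1 (Homo sapiens), read by HPLC, with a stated time of 24 h; on this read-out higher numbers stand for weaker inhibition and lower numbers for stronger inhibition. For the measured compounds named here, compound 2 `Cc1ccccc1N(C)C(=O)c1ccc(-c2ccc(O)cc2Cl)o1` gives 14 nM in this assay; the step of a 1.4-fold higher number from compound 1 to compound 2 (0.15 log units; within the scatter) is the only single-point change measured so far and it sits on the phenol ring. Compound 3 `Cc1ccc(F)cc1N(C)C(=O)c1ccc(-c2ccc(O)cc2)o1` gives 12 nM in this assay, alongside compound 2 and compound 1 within the scatter of each of them; the three numbers are indistinguishable.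

Compound 4 `Cc1ncccc1N(C)C(=O)c1ccc(-c2ccc(O)cc2)o1` carries 2-methylpyridin-3-yl in place of 5-fluoro-2-methylphenyl on an amide-type nitrogen. Going by the values given here, no measured step touches the aryl group on the amide-type nitrogen, so the one step on record, from the phenol ring, does not bear on this change. Among the compounds with values here, the data give no ground for a direction, and since every variation so far has stayed within the scatter, compound 4 is expected to show a 1.3-fold higher number from compound 3 to compound 4 (0.10 log units; within the scatter). Compound 4 is estimated at 15 nM in this assay, with a range from 5 nM to 50 nM.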

Compound 4, half-maximal inhibitory concentration: 43 nM
Compound 4: middle estimate off by 2.9-fold (0.46 log units), on the low side; low and high end bracket the measured number.
By their numbers in this assay, from the lowest: compounds 1, 3 and 2 (each within the scatter of the next); then compound 4.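

In this assay, for the compounds shown here, the swap of 5-fluoro-2-methylphenyl for 2-methylpyridin-3-yl on the amide-type nitrogen gives a 3.6-fold higher number from compound 3 to compound 4 (0.55 log units; beyond the scatter) and is the first single change to pass beyond the scatter. Going by these compounds alone, the step is modest, but it shows that this position responds to the identity of the aryl group, whereas the one earlier step, on the phenol ring, stayed within the scatter. No measurement on hand accounts for the higher number.

As far as these compounds go, the step replaces a fluorine-bearing carbon ring with a ring holding one hetero atom, so the contribution of each difference stays open. Also open, from the compounds shown here alone, is how this position would respond to other aryl groups, such as a methoxy-bearing or amino-bearing phenyl on the amide-type nitrogen.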